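This account rests on a few compounds, and the source may have more. Where it says the series, first, only, none or still open, it means among the compounds named here.

In an ADME assay on WI-38 cells (Homo sapiens) for cytotoxicity, read by MTT assay, with a stated time of 72 h (on this read-out lower numbers stand for stronger inhibition and higher numbers for weaker inhibition), compound 1 (`O=C(CCc1cccc2c1B(O)OC2)Nc1ccc(Br)cc1`) gives 42000 nM and compound 2 (`O=C(CCc1cccc2c1B(O)OC2)Nc1cccc(Br)c1`) gives 20000 nM while compound 3 (`O=C(CCc1cccc2c1B(O)OC2)Nc1cccc(I)c1`) gives 71000 nM as its reading. Compound 3 thus lies within the scatter of compound 1 (a 1.7-fold higher number from compound 1 to compound 3 (0.23 log units; within the scatter)) and above compound 2 (a 3.6-fold higher number from compound 2 to compound 3 (0.55 log units; beyond the scatter)). The next compound, compound 4 (`O=C(CCc1cccc2c1B(O)OC2)Nc1cccc(-c2ccccc2)c1`), carries phenyl in place of iodo on an aromatic carbon. The measured steps bear on this change only indirectly. Moving the bromo group gave a modest change (a 2.1-fold lower number from compound 1 to compound 2 (0.32 log units; beyond the scatter)), and the exchange of bromo for iodo was also modest. Within the data shown here, none of these steps brings in a ring, so the data hold no direct precedent for phenyl. With steps this small across compound 1, compound 2 and compound 3, no step beyond the scatter is expected in this assay, with at most a slight lean towards a lower number. The expected change is small (a 1.8-fold lower number from compound 3 to compound 4 (0.25 log units; within the scatter)). Compound 4 is estimated at 40000 nM (expected range 14000 nM to 100000 nM).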

Compound 4, half-maximal inhibitory concentration: 12000 nM
Estimate against measurement, compound 4: 3.3-fold (0.52 log units) above, and the stated range ends above it.
By their numbers in this assay, from the lowest: compounds 4 and 2 (each within the scatter of the next); then compounds 1 and 3 (each within the scatter of the next).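

In this assay the place held by a halogen in compound 2 and compound 3 also takes a whole six-membered aromatic ring, and phenyl for iodo gives a 5.9-fold lower number from compound 3 to compound 4 (0.77 log units; beyond the scatter) as a step in its own right. Set against bromo at the same place, phenyl gives a 1.7-fold lower number from compound 2 to compound 4 (0.22 log units; within the scatter) and so stays level with it, which shows that a group of six heavy atoms here does not by itself raise the number. Nothing available accounts for why phenyl sits with bromo and apart from iodo.

Going by these compounds, it remains open whether an amine, a carboxylic acid or a saturated cyclohexyl ring at this place would keep the number at this level. Also open, on these data alone, is how phenyl would read on the carbon that carries bromo in compound 1.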